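The source may hold more compounds than are shown below. What is called first, only, known or untested is meant among the compounds shown, and "the series" means these compounds.

Two compounds share one core and are compared in a functional assay on HEK293 cells for agonist activity at growth hormone secretagogue receptor type 1 (Homo sapiens), read by HTRF and inositol phosphate accumulation, with a stated time of 90 min, in the presence of a further agent that is not named here; on this read-out lower numbers stand for smaller maximal responses and higher numbers for larger maximal responses. Compound 1 `Cc1ccc2[nH]c(C(=O)N[C@H]3CN(S(=O)(=O)c4ccccc4)C[C@@H]3C(=O)NCCN(C)C)cc2c1` gives 93% in this assay, the higher of the two numbers recorded, though its lead over compound 2 is within the scatter. For the measured compounds named here, compound 2 `Cc1ccc2[nH]c(C(=O)N[C@H]3CN(S(=O)(=O)c4cccnc4)C[C@@H]3C(=O)NCCN(C)C)cc2c1` gives 90% in this assay; the only measured step, a number 3 percentage points lower from compound 1 to compound 2 (within the scatter), changes a pyridin-3-yl for a phenyl on a sulfonyl sulfur and leaves the maximal response essentially unchanged.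

Compound 3 `Cc1ccc2[nH]c(C(=O)N[C@H]3CN(S(=O)(=O)c4ccccc4)C[C@H]3C(=O)NCCN(C)C)cc2c1` has not yet been measured. It differs from compound 1 in this way: the two compounds have the same atoms and bonds and differ only in configuration as drawn: 1 of 2 stereo elements differ; a stereocentre at a saturated ring carbon is drawn S in compound 1 and R in compound 3

Going by the values given here, no measured step concerns a change of configuration, so the single step from compound 1 to compound 2 gives no direct guide to what this inversion will do; it shows only that the maximal response in this assay has so far been stable to a change on the sulfonyl group. Without data on the inverted stereocentre, the step of a number 13 percentage points lower from compound 1 to compound 3 (beyond the scatter) is expected as a modest fall with a wide range, and compound 3 is estimated to reach 80%, between 45% and 100%.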

Compound 3, largest response reached (Emax), in percent of the reference or control that the assay uses: 72%
The estimate for compound 3 lay 8 percentage points above the measured number; the range from low to high includes it.
By their numbers in this assay, from the lowest: compound 3; then compounds 2 and 1 (each within the scatter of the next).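

In this assay, for the compounds shown here, inverting a single stereocentre at a saturated ring carbon gives a number 21 percentage points lower from compound 1 to compound 3 (beyond the scatter), the first step here to lie beyond the scatter, which the earlier change on the sulfonyl group did not do. The maximal response at this receptor therefore depends on how this ring carbon is drawn, yet the inversion lowers the response without abolishing it, as compound 3 still gives 72%. No group enters or leaves, so the fall can be assigned to this stereocentre rather than to any change of atoms, and the ground for that is: the fact that compounds 1 and 3 differ only in the configuration as drawn

The compounds shown leave open whether inverting the other stereocentre, or both together, would change the response as much, and whether the same inversion would have a similar effect with pyridin-3-yl on the sulfonyl sulfur. Also open, on these data alone, is how the response would move at either configuration if a primary amine or a carboxylic acid took the place of the dimethylamino group at the end of the side chain.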